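One Ring Swap Repeated on a Second Core

The compounds below may be only part of what the source reports. "The series", "measured", "known", "first", "only" and "open" are said of these compounds alone.

Compound 1 `O=c1ccn(C2CN(S(=O)(=O)c3ccccc3[N+](=O)[O-])c3ccccc3CO2)c(=O)[nH]1` and compound 2 `O=[N+]([O-])c1ccccc1S(=O)(=O)N1CC(n2cnc3ncnc(Cl)c32)OCc2ccccc21` share a core and differ by a group of 10 heavy atoms (5 carbon, 4 nitrogen, 1 chlorine; one five-membered aromatic ring with 2 hetero atoms, one six-membered aromatic ring with 2 hetero atoms) in place of a group of 8 heavy atoms (4 carbon, 2 nitrogen, 2 oxygen; one six-membered aromatic ring with 2 hetero atoms), on a saturated ring carbon. In a functional assay on MCF7 cells (Homo sapiens) for antiproliferative activity (a higher number here means a weaker inhibitor, a lower number a stronger inhibitor), compound 1 gives 45200 nM, while compound 2 gives 920 nM, which is a 49-fold lower number from compound 1 to compound 2 (1.69 log units; beyond the scatter). Compound 3 `O=c1ccn(C2CN(S(=O)(=O)c3ccc([N+](=O)[O-])cc3)c3ccccc3CO2)c(=O)[nH]1` differs from compound 1 by 4-nitrophenyl in place of 2-nitrophenyl on a sulfonyl sulfur; in this assay compound 3 gives 39800 nM, and a 1.1-fold lower number from compound 1 to compound 3 (0.06 log units; within the scatter). Compound 4 `O=[N+]([O-])c1ccc(S(=O)(=O)N2CC(n3cnc4ncnc(Cl)c43)OCc3ccccc32)cc1` has not yet been measured; it differs from compound 3 by a group of 10 heavy atoms (5 carbon, 4 nitrogen, 1 chlorine; one five-membered aromatic ring with 2 hetero atoms, one six-membered aromatic ring with 2 hetero atoms) in place of a group of 8 heavy atoms (4 carbon, 2 nitrogen, 2 oxygen; one six-membered aromatic ring with 2 hetero atoms), on a saturated ring carbon, made at the same place as the change from compound 1 to compound 2, so it is the same change carried onto the other core. If the step carries over, compound 4 is expected to give 900 nM in this assay, within 300 nM to 3000 nM. That estimate means a 44-fold lower number from compound 3 to compound 4 (1.65 log units; beyond the scatter) and rests on a 49-fold lower number from compound 1 to compound 2 (1.69 log units; beyond the scatter), together with the close numbers of compound 1 and compound 3.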

Compound 4, half-maximal inhibitory concentration: 1220 nM
Compound 4: the middle estimate sits 1.4-fold (0.13 log units) below what was measured; the measured number falls inside the stated range.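

In this assay, the exchange on the saturated ring carbon gives a 33-fold lower number from compound 3 to compound 4 (1.51 log units; beyond the scatter), and the step carries over to the second core with a size that matches the first: the same change on two cores in this assay, a 49-fold lower number (1.69 log units; beyond the scatter) from compound 1 to compound 2 and a 33-fold lower number (1.51 log units; beyond the scatter) from compound 3 to compound 4, 1.5-fold (0.18 log units) apart, within the scatter of two such steps

The exchange of 2-nitrophenyl for 4-nitrophenyl gives a 1.3-fold higher number from compound 2 to compound 4 (0.12 log units; within the scatter), which leaves that change without a measurable effect with either group on the saturated ring carbon: the same change on two cores in this assay, a 1.1-fold lower number (0.06 log units; within the scatter) from compound 1 to compound 3 and a 1.3-fold higher number (0.12 log units; within the scatter) from compound 2 to compound 4, 1.5-fold (0.18 log units) apart, within the scatter of two such steps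

This shows that the step transfers between these two closely related cores, but it does not show why the step is so large or that it would hold on a core with a different group on the sulfonyl sulfur.

As far as these compounds go, it remains open which part of the entering group carries the step. An amine in place of the chlorine, or a methyl group in place of the nitrophenyl on the sulfonyl sulfur, could test how far the step extends.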